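A few compounds are considered here, and "the series" means these few. Any claim that something is new, unique, unknown or untested is made for them only; others in the source may bear on it.

Of the compounds shown here, three that share one core have been measured in a functional assay on NCI-H460 cells (Homo sapiens) for inhibition, with a stated time of 72 h; on this read-out lower numbers stand for stronger inhibition and higher numbers for weaker inhibition. Compound 1 `COc1ccc(S(=O)(=O)N2CCc3cccc(-c4ccc(F)nc4)c32)cc1` carries a 6-fluoropyridin-3-yl group and gives 135 nM, while compound 2 `COc1ccc(S(=O)(=O)N2CCc3cccc(-c4ccc(F)cc4)c32)cc1` carries a 4-fluorophenyl group and gives 95.5 nM. Compound 3 `COc1ccc(-c2cccc3c2N(S(=O)(=O)c2ccc(OC)cc2)CC3)cc1`, with a 4-methoxyphenyl group, gives 302 nM, the highest number of the three and so the weakest inhibition, with its steps to both others beyond the scatter.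

Compound 4 `COc1ccc(S(=O)(=O)N2CCc3cccc(-c4cccc(F)c4)c32)cc1` has not yet been measured. It has 3-fluorophenyl in place of 4-methoxyphenyl on an aromatic carbon of the shared core: 3-fluorophenyl in place of 4-methoxyphenyl on an aromatic carbon.

Among the compounds with values here, two measured steps bear most directly on this change. They are a 3.2-fold higher number from compound 2 to compound 3 (0.50 log units; beyond the scatter) and a 2.2-fold higher number from compound 1 to compound 3 (0.35 log units; beyond the scatter), both modest. The two fluoro-bearing compounds themselves differ by only a 1.4-fold lower number from compound 1 to compound 2 (0.15 log units; within the scatter). Within the data shown here, none of the measured compounds has the 3-fluorophenyl group, so the effect of this placement of the fluoro is untested.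

Leaving 4-methoxyphenyl for a fluoro-bearing ring is therefore expected to lower the number modestly in this assay, and the estimated size is a 2.3-fold lower number from compound 3 to compound 4 (0.37 log units; beyond the scatter). For compound 4 the expected value is 130 nM, with an estimated range of 55 nM to 300 nM.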

Compound 4, half-maximal inhibitory concentration: 167 nM
Estimate against measurement, compound 4: 1.3-fold (0.11 log units) below, and the stated range covers the measured number.
By their numbers in this assay, from the lowest: compounds 2, 1, 4 and 3 (each within the scatter of the next, the first and the last beyond it).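

In this assay, this place on the shared core tolerates a moved fluoro and a changed ring: 3-fluorophenyl in place of 4-fluorophenyl gives a 1.7-fold higher number from compound 2 to compound 4 (0.24 log units; within the scatter) and 3-fluorophenyl in place of 6-fluoropyridin-3-yl gives a 1.2-fold higher number from compound 1 to compound 4 (0.09 log units; within the scatter), so the three fluoro-bearing compounds cannot be told apart on this read-out. The change away from 4-methoxyphenyl gives a 1.8-fold lower number from compound 3 to compound 4 (0.26 log units; within the scatter) and is smaller than the scatter, so compound 3 no longer stands clearly apart from every fluoro-bearing compound, although its steps to compound 1 and compound 2 remain beyond the scatter. No measurement at hand offers a reason for any of these numbers.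

Within the data shown here, every group at this place so far is a six-membered aromatic ring carrying a fluoro or a methoxy, so the effect of a plain phenyl group with neither, or of a ring bearing an amine or a carboxylic acid, remains open. Going by these compounds, it is also open whether this place accepts a saturated ring such as morpholine or a longer chain in place of an aromatic ring.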